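Compound 3: swapping 2-fluorophenyl for an aminopyridine

A few compounds are considered here, and "the series" means these few. Any claim that something is new, unique, unknown or untested is made for them only; others in the source may bear on it.

Measured so far in a functional assay on MCF7 cells (Homo sapiens) for cytotoxicity, read by MTT assay and propidium iodide staining, with a stated time of 24 h; on this read-out lower numbers stand for stronger inhibition and higher numbers for weaker inhibition:
- compound 1 `O=C(CSc1nnc(-c2ccncc2)o1)c1ccc(Br)cc1` gives 4230 nM
- compound 2 `O=C(CSc1nnc(-c2ccccc2F)o1)c1ccc(Br)cc1` gives 240 nM

Compound 2 holds the lower of the two numbers in this assay and so stands as the stronger of the pair, with compound 1 higher by a margin beyond the scatter. The next structure, compound 3 `Nc1cc(-c2nnc(SCC(=O)c3ccc(Br)cc3)o2)ccn1`, has 2-aminopyridin-4-yl in place of 2-fluorophenyl on an aromatic carbon.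

Among the compounds with values here, one measured step bears on this change (an 18-fold lower number from compound 1 to compound 2 (1.25 log units; beyond the scatter)). It is large and is also a swap at this carbon, 2-fluorophenyl in place of pyridin-4-yl. Within the data shown here, the group entering compound 3 resembles the pyridin-4-yl of compound 1 (4230 nM) with an amino group added, and no measured step isolates that addition. A large step towards a higher number is therefore expected (an 8.3-fold higher number from compound 2 to compound 3 (0.92 log units; beyond the scatter)), probably somewhat smaller than the measured one, though the evidence is a single pair. For compound 3 the estimated value is 2000 nM, with an expected range from 450 nM to 8000 nM.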

Compound 3, half-maximal inhibitory concentration: 200 nM
Beside the measured number, compound 3's estimate is 10-fold (1.00 log units) above it; measured number outside the range, below it.
By their numbers in this assay, from the lowest: compounds 3 and 2 (each within the scatter of the next); then compound 1.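

In this assay, 2-aminopyridin-4-yl in place of 2-fluorophenyl on this aromatic carbon gives a 1.2-fold lower number from compound 2 to compound 3 (0.08 log units; within the scatter) as the measured step, so at this position a nitrogen-containing ring and a carbon-only ring can sit at matching numbers, and a ring with a hetero atom does not by itself carry the high number of compound 1. Amino in place of hydrogen on the pyridin-4-yl group gives a 21-fold lower number from compound 1 to compound 3 (1.33 log units; beyond the scatter) as a second reading, which isolates that single addition and shows that it alone separates a weak compound from one level with compound 2 in this assay. Nothing at hand explains why this addition has so large an effect.

Open, as far as these compounds go, is whether the amino group itself is required, or whether a methylamino, dimethylamino, hydroxyl or methoxy group on the pyridin-4-yl ring would serve in the same way. Also open, from the compounds shown here alone, is what an amino group would do on a carbon-only phenyl ring at this carbon, and whether the 2-fluorophenyl result extends to a chloro or methyl group in place of the fluorine.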